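Amide nitrogen changes around compound 3

The source may report more compounds than this note shows. Statements on the series, on what has been measured and on what is new or still open speak of the compounds shown alone.

Measured in a functional assay on BaF3 cells (Mus musculus) for antiproliferative activity, read by CCK-8 assay and cell counting, with a stated time of 76 h (a higher number here means a weaker inhibitor, a lower number a stronger inhibitor), as follows
- compound 1 `COc1cc2nccc(Oc3ccc(Nc4nn(C)cc4C(=O)NCc4ccccc4)cc3)c2cc1C(N)=O` gives > 10000 nM (a limit)
- compound 2 `COc1cc2nccc(Oc3ccc(Nc4nn(C)cc4C(=O)NC45CCC(CC4)CC5)cc3)c2cc1C(N)=O` gives > 10000 nM (a limit)
- compound 3 `COc1cc2nccc(Oc3ccc(Nc4nn(C)cc4C(=O)NC4CCCCC4)cc3)c2cc1C(N)=O` gives 4800 nM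

Within the data shown here, compound 3 holds the only true number and the lowest value. Its two neighbours sit at the limit of > 10000 nM in this assay, at which 2 of the 3 values shown sit (a limit), so the steps (an at least 2.0-fold lower number from compound 1 to compound 3 (0.31 log units; beyond the scatter)) and (an at least 2.0-fold lower number from compound 2 to compound 3 (0.31 log units; beyond the scatter)) give minimum sizes only. Compound 4 `COc1cc2nccc(Oc3ccc(Nc4nn(C)cc4C(=O)N4CCCCC4)cc3)c2cc1C(N)=O` carries piperidin-1-yl in place of cyclohexylamino on a carbonyl carbon. Among the measured compounds shown here, no measured step removes the amide hydrogen, so these two steps bear on it only indirectly, showing that this assay responds to changes at this amide. A weaker result is expected, with an estimated step (a 1.9-fold higher number from compound 3 to compound 4 (0.27 log units; within the scatter)) of modest size. Compound 4 is estimated at 9000 nM (range 3500 nM to 25000 nM).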

Compound 4, half-maximal inhibitory concentration: 5650 nM
Beside the measured number, compound 4's estimate is 1.6-fold (0.20 log units) above it, within the range that was stated.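

Loss of the amide hydrogen, with piperidin-1-yl in place of cyclohexylamino on a carbonyl carbon, produces no readable shift in this assay (a 1.2-fold higher number from compound 3 to compound 4 (0.07 log units; within the scatter)). Against the other two compounds, piperidin-1-yl gives only floors that lie within the scatter (an at least 1.7-fold lower number from compound 2 to compound 4 (0.24 log units; that floor lies within the scatter)) and (an at least 1.7-fold lower number from compound 1 to compound 4 (0.24 log units; that floor lies within the scatter)). These steps stay minimum sizes because compound 1 and compound 2 are held at a limit: the limit of > 10000 nM in this assay, at which 2 of the 4 values shown sit.

Going by these compounds, whether morpholin-4-yl or dimethylamino on the same carbonyl carbon keeps this level remains open. So does whether any group here reads clearly lower than compound 3 and compound 4.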